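Expected Lipophilicity of Compound 3 after a Methoxy Addition

The compounds below may be only part of what the source reports. "The series", "measured", "known", "first", "only" and "open" are said of these compounds alone.

Of the compounds shown here, two have so far been measured in a physicochemical assay for lipophilicity; a lower number here means a more polar compound, a higher number a more lipophilic compound. Compound 1 `CCCc1ccc2[nH]c(-c3ccccc3)c(C3=C(Br)C(=O)NC3=O)c2c1` gives 3.43. Compound 2 `CCCCc1ccc2[nH]c(-c3ccccc3)c(C3=C(Br)C(=O)NC3=O)c2c1` gives 3.74. For the measured compounds named here, the single measured step, a number 0.31 log units higher from compound 1 to compound 2 (beyond the scatter), places compound 2 highest of the two numbers, with compound 1 as its nearest neighbour, lying that much lower.

Compound 3 `CCCCc1ccc2[nH]c(-c3cccc(OC)c3)c(C3=C(Br)C(=O)NC3=O)c2c1` has not yet been measured. It differs from compound 2 by methoxy in place of hydrogen on an aromatic carbon. The step from compound 1 to compound 2 concerns a methyl added to a saturated chain, not a methoxy on an aromatic carbon, so it bears only loosely on the present change: it shows that adding a small group to the shared core can move this assay by a modest amount, but it offers no direct guide for a methoxy. Going by the values given here, with no closer precedent, the shift in this assay is expected to be small, and a change within the scatter in either direction is anticipated. For compound 3 the step is estimated as a number 0.01 log units higher from compound 2 to compound 3 (within the scatter). Compound 3 is expected to give 3.75, within a range from 3.4 to 4.1.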

Compound 3, partition coefficient: 3.81
Estimate against measurement, compound 3: 0.06 log units below, and the stated range covers the measured number.
By their numbers in this assay, from the lowest: compound 1; then compounds 2 and 3 (each within the scatter of the next).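

With phenyl changed to 3-methoxyphenyl, this assay shows a number 0.07 log units higher from compound 2 to compound 3 (within the scatter), so compound 2 and compound 3 cannot be told apart in this read-out. For the compounds shown here, this gives the first measured reading for a change on an aromatic carbon of this six-membered ring, meta to a large group, since the earlier step, a number 0.31 log units higher from compound 1 to compound 2 (beyond the scatter), concerned only the saturated chain. At this one position, a methoxy group, with its 2 heavy atoms and 1 hydrogen-bond acceptor, leaves the number within the usual scatter, but nothing at hand gives a reason for this result.

The compounds shown leave open whether another group on this same carbon, such as an amine or a carboxylic acid, would also stay within the scatter, and whether methoxy on a different carbon of this ring would behave as it does here. They also leave open whether a longer chain in place of the present saturated chain would move the number again, and whether it would do so equally with phenyl and with 3-methoxyphenyl on the shared core.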